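This account rests on a few compounds, and the source may have more. Where it says the series, first, only, none or still open, it means among the compounds named here.

Measured in a functional assay on MCF7 cells (Homo sapiens) for inhibition, read by sulforhodamine B assay; a lower number here means a stronger inhibitor, a higher number a weaker inhibitor:
- Compound 1 `CCCc1ccc(NC2=CC(=O)c3nc4n(c3C2=O)[C@H]2OC[C@@H](O)[C@H]2OC4)cc1`: 4660 nM
- Compound 2 `CCOc1ccc(NC2=CC(=O)c3nc4n(c3C2=O)[C@H]2OC[C@@H](O)[C@H]2OC4)cc1`: 1430 nM
- Compound 3 `O=C1C(NC2CC2)=CC(=O)c2c1nc1n2[C@H]2OC[C@@H](O)[C@H]2OC1`: > 16000 nM, a limit of the assay and not a number

Compound 2 has the lower of the two exact numbers, which makes it the stronger inhibitor of that pair. Compound 3 offers no exact number for comparison, and its entry is the limit of > 16000 nM in this assay, at which 1 of the 3 values shown sits.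

The next compound, compound 4 `O=C1C=C(Nc2ccccc2)C(=O)c2c1nc1n2[C@H]2OC[C@@H](O)[C@H]2OC1`, has hydrogen in place of ethoxy on an aromatic carbon, turning 4-ethoxyphenyl into phenyl (hydrogen in place of ethoxy on an aromatic carbon). Within the data shown here, one measured step bears on this carbon: a 3.3-fold lower number from compound 1 to compound 2 (0.51 log units; beyond the scatter), with ethoxy in place of propyl. Among the measured compounds shown here, that modest step shows that the group at this carbon can shift the number in this assay, but no measured compound shows the group removed. A modest step is therefore expected again, this time towards a higher number, since compound 2 is the best of the exact values at 1430 nM. The expected change is a 2.4-fold higher number from compound 2 to compound 4 (0.39 log units; beyond the scatter). For compound 4, the estimated value is 3500 nM, with an expected range of 1200 nM to 11000 nM.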

Compound 4, half-maximal inhibitory concentration: > 4000 nM
Compound 4: only a limit was reported; the forecaster's own chance of this, stated with the estimate: 10%; middle value at least 1.1-fold (0.05 log units) from the limit.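

In this assay, putting hydrogen in place of ethoxy gives an at least 2.7-fold higher number from compound 2 to compound 4 (0.44 log units; beyond the scatter), so removing the group from this carbon weakens inhibition. Among these compounds, the earlier compounds showed only one group swapped for another, whereas this pair compares 4-ethoxyphenyl with a plain phenyl that has no group at this carbon. Compound 4 has only a limit and not an exact number, and the step from compound 1 to compound 4 cannot be read: the limit of > 4000 nM in this assay, at which 1 of the 4 values shown sits.

As far as these compounds go, it therefore stays open how much weaker compound 4 really is, and whether the propyl group of compound 1 offers any gain over hydrogen. The compounds shown also leave open how other groups at this carbon would compare, such as a methoxy, a hydroxyl, an amine or a longer chain like butoxy.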